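The source may hold more compounds than are shown below. What is called first, only, known or untested is meant among the compounds shown, and "the series" means these compounds.

Measured in an assay on cells for displacement of a labelled ligand from Toll-like receptor 8 (Homo sapiens), read by TR-FRET, with a stated time of 30 min (on this read-out lower numbers stand for stronger inhibition and higher numbers for weaker inhibition), so far:

Compound 1, `Cn1cc(-c2ccc3nc(N4CCN(C5CCC5)CC4)ncc3c2)ccc1=O`: 2400 nM
Compound 2, `Cc1cc(-c2ccc(=O)n(C)c2)cc2cn(C3CCNCC3)nc12`: 7600 nM

Of these two numbers, compound 2 gives the higher one; compound 1 gives a lower number, and the gap between them is beyond the usual scatter of repeated measurements, so compound 1 is the stronger inhibitor of the two in this assay. Compound 3, `Cc1cc(-c2cc(C)c3nn(C4CCNCC4)cc3c2)cn(C)c1=O`, has not yet been measured. It differs from compound 2 in one place: methyl in place of hydrogen on an aromatic carbon, a methyl in place of hydrogen on an aromatic carbon. Among the measured compounds shown here, no measured pair in this set differs in just one such place, so there is no measured step to lean on. Compound 3 is expected to move from compound 2 by about a 1.5-fold lower number from compound 2 to compound 3 (0.18 log units; within the scatter), a step that may well fall within the scatter. Compound 3 is estimated to give 5000 nM in this assay, with a likely range from 1500 nM to 20000 nM.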

Compound 3, half-maximal inhibitory concentration: 1700 nM
Beside the measured number, compound 3's estimate is 2.9-fold (0.47 log units) above it; the measured number falls inside the stated range.
By their numbers in this assay, from the lowest: compounds 3 and 1 (each within the scatter of the next); then compound 2.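

In this assay the swap of hydrogen for methyl on an aromatic carbon gives a 4.5-fold lower number from compound 2 to compound 3 (0.65 log units; beyond the scatter) as a modest step, yet one beyond the scatter. Among the compounds shown here, as the only measured step in this set, it shows that this position, on a six-membered aromatic ring with 1 nitrogen and two atoms from the ring nitrogen, is sensitive to a single extra carbon, with inhibition getting stronger rather than weaker. No measurement at hand explains why this methyl has that effect.

On these data alone, whether a longer chain such as ethyl, or a different group such as chlorine or methoxy, would act the same way at this position remains open. So does whether this methyl would have a similar effect on the core of compound 1.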